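Aryl ketone swap on the shared core: compound 4

The source may hold more compounds than are shown below. What is called first, only, known or untested is meant among the compounds shown, and "the series" means these compounds.

Measured compounds:
compound 1 `COc1cc(-c2nnc3n2NC(c2ccco2)C(C(=O)c2ccco2)S3)cc(OC)c1OC`: > 100000 nM
compound 2 `COc1cc(-c2nnc3n2NC(c2ccco2)C(C(=O)c2ccc(C)cc2)S3)cc(OC)c1OC`: 17400 nM
compound 3 `COc1cc(-c2nnc3n2NC(c2ccco2)C(C(=O)c2ccccc2F)S3)cc(OC)c1OC`: > 100000 nM

In a functional assay on HepG2 cells (Homo sapiens) for cytotoxicity, read by MTT assay, with a stated time of 48 h (a lower number here means a stronger inhibitor, a higher number a weaker inhibitor), compound 3 is reported only as a limit, > 100000 nM, and not as a number. Compound 1 likewise sits at a limit in this assay, > 100000 nM. Among the three, only compound 2 gives a number in this assay, 17400 nM. Compound 1 and compound 3 both sit at the limit of > 100000 nM in this assay, at which 2 of the 3 values shown sit.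

Compound 4 `COc1cccc(C(=O)C2Sc3nnc(-c4cc(OC)c(OC)c(OC)c4)n3NC2c2ccco2)c1` is not yet measured. It differs from compound 3 at one place: 3-methoxyphenyl in place of 2-fluorophenyl on a carbonyl carbon.

Going by the values given here, two measured steps touch the same position. an at least 5.7-fold higher number from compound 2 to compound 3 (0.75 log units; beyond the scatter) shows that a phenyl ring carrying a 4-methyl group reads lower than the 2-fluorophenyl ketone. a step that the two limits leave unreadable from compound 1 to compound 3 is unreadable, as both ends are limits. The step from compound 3 to compound 4 exchanges one substituted phenyl for another, so the outcome is expected to lie somewhere between the behaviour of compound 2 and that of compound 3, with a real chance that compound 4 again returns only a limit.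

For compound 4 the expected value in this assay is 50000 nM, with a range from 15000 nM to 150000 nM. The step this estimate implies is an at least 2.0-fold lower number from compound 3 to compound 4 (0.30 log units; that floor lies within the scatter), expected to run toward a lower number, though the limit on compound 3 leaves its size uncertain.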

Compound 4, half-maximal inhibitory concentration: > 100000 nM
Compound 4: a limit, no number; the forecaster's own chance of this, stated with the estimate: 45%; middle value at least 2.0-fold (0.30 log units) away from the limit.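

In this assay the 3-methoxyphenyl ketone compound 4 falls with the limit compounds and not with the 4-methylphenyl ketone compound 2, with an at least 5.7-fold higher number from compound 2 to compound 4 (0.75 log units; beyond the scatter). The steps from compound 1 and compound 3 to compound 4 cannot be read, as both ends of each are limits. A second substituted phenyl on the carbonyl carbon now gives no number, so a substituted phenyl as such is not enough at this position, and compound 2 stands alone among the four: the limit of > 100000 nM in this assay, at which 3 of the 4 values shown sit.

Still open, from the compounds shown here alone, is whether the number of compound 2 depends on the methyl group or on where it sits on the ring, which a 3-methylphenyl or a 4-methoxyphenyl ketone would help separate. Going by these compounds, the order among compound 1, compound 3 and compound 4 also remains unknown.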